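Chloro for methyl on the aryl ring of compound 2

This account rests on a few compounds, and the source may have more. Where it says the series, first, only, none or still open, it means among the compounds named here.

In an assay on LX2 cells for inhibition of COL1A1 promoter (Homo sapiens), read by a luciferase reporter, with a stated time of 24 h, tested at 50 uM (on this read-out higher numbers stand for a stronger effect at the one concentration tested and lower numbers for a weaker effect), compound 2 `Cc1ccc(-n2cc(C(=O)Nc3cc(F)cc(F)c3)c(=O)c3ccc(N(C)C)nc32)cc1OCCCCCCC[N+]1(C)CCCC1` gives 55.9%, the highest of the two numbers in hand, while compound 1 `CN(C)c1ccc2c(=O)c(C(=O)Nc3cc(F)cc(F)c3)cn(-c3ccc(Cl)c(OCCCCCCC[N+]45CCN(CC4)CC5)c3)c2n1` gives 18.7%, a gap beyond the scatter. Compound 3 `CN(C)c1ccc2c(=O)c(C(=O)Nc3cc(F)cc(F)c3)cn(-c3ccc(Cl)c(OCCCCCCC[N+]4(C)CCCC4)c3)c2n1` is compound 2 with one change: chloro in place of methyl on an aromatic carbon. Within the data shown here, no step between measured compounds tells how much this exchange is worth. The value of compound 1 suggests caution, so the estimated step of a number 15.9 percentage points lower from compound 2 to compound 3 (beyond the scatter) in this assay is a moderate loss beyond the scatter. Compound 3 is therefore expected to give 40% in this assay, with a range from 15% to 65%.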

Compound 3, a percentage reported as inhibition, at one concentration (the size of the read-out at that concentration, not a potency): 76.1%
Beside the measured number, compound 3's estimate is 36.1 percentage points below it, and the stated range ends below it.
By their numbers in this assay, from the lowest: compound 1; then compound 2; then compound 3.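

In this assay, chloro in place of methyl on this aromatic carbon brings a gain, a number 20.2 percentage points higher from compound 2 to compound 3 (beyond the scatter), so the position accepts chloro at least with the five-membered ring group at the end of the chain. With chloro kept, exchanging the group at the chain end gives a large step, a number 57.4 percentage points higher from compound 1 to compound 3 (beyond the scatter), showing that the outcome depends on that end as well. No measurement at hand gives a reason for either step. On these data alone, whether fluoro or methoxy on this carbon would do as well remains open, as does whether the gain from chloro would survive a shorter chain.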